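This account rests on a few compounds, and the source may have more. Where it says the series, first, only, none or still open, it means among the compounds named here.

Working notes on the series. In a functional assay on A549 cells (Homo sapiens) for antiproliferative activity, read by MTT assay, with a stated time of 72 h (a higher number here means a weaker inhibitor, a lower number a stronger inhibitor), compound 1 (`c1ccc(COc2ccccc2Nc2ncnc3cc4c(cc23)OCCOCCO4)cc1`) reads > 100000 nM, which is a limit of the assay and not a number. Compound 2 (`FC(F)(F)c1ccc(COc2ccccc2Nc2ncnc3cc4c(cc23)OCCOCCOCCO4)cc1`) reads > 100000 nM, which is also a limit. No measured number is therefore available for compound 1 to step from.

Compound 3 (`FC(F)(F)c1ccc(COc2ccccc2Nc2ncnc3cc4c(cc23)OCCOCCO4)cc1`) is compound 1 with a single change: trifluoromethyl in place of hydrogen on an aromatic carbon, with trifluoromethyl in place of hydrogen on an aromatic carbon, para to a large group. Going by the values given here, no measured pair yet shows the size of this change.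

The expectation rests on the limit of > 100000 nM in this assay, at which 2 of the 2 values shown sit, and is for no step beyond the scatter in this assay, in either direction. The estimated step, a number no higher from compound 1 to compound 3 (the limit leaves the size open), is small, and a reading at the same limit is the likeliest result. Compound 3 is expected at 100000 nM with an estimated range of 25000 nM to 200000 nM as the span of a numeric reading.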

Compound 3, half-maximal inhibitory concentration: > 100000 nM
Compound 3 was reported as a limit; the forecaster's own chance of this, stated with the estimate: 70%; the middle value lies on the limit itself.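

Going by these compounds alone, compound 1 and compound 3 both read as limits of the assay and not as numbers, so no step between them can be read. The compounds shown leave open what size of step trifluoromethyl in place of hydrogen gives, and which change, if any, would bring a numeric reading.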